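A few compounds are considered here, and "the series" means these few. Any claim that something is new, unique, unknown or untested is made for them only; others in the source may bear on it.

Of the compounds shown here, two sharing one core have been measured in an assay on isolated protein for inhibition of protein deacetylase HDAC6 (Homo sapiens), read by fluorescence, with a stated time of 1 h, tested at 100 nM; on this read-out lower numbers stand for less inhibition and higher numbers for more inhibition at the one concentration tested (going by the name of the read-out). Compound 1 `Cc1ccc(CN2CCC(c3noc(COc4ccc(/C=C/C(=O)NO)cc4)n3)CC2)cc1` gives 76%, and compound 2 `COc1ccc(CN2CCC(c3noc(COc4ccc(/C=C/C(=O)NO)cc4)n3)CC2)cc1` gives 75%. Compound 2 holds the lower of the two numbers, yet the step of a number 1 percentage points lower from compound 1 to compound 2 (within the scatter) lies within the scatter, so the two compounds cannot be told apart in this assay. Compound 3 `O=C(/C=C/c1ccc(OCc2nc(C3CCN(Cc4ccccc4[N+](=O)[O-])CC3)no2)cc1)NO` has not been measured. It differs from compound 2 in one place: 2-nitrophenyl in place of 4-methoxyphenyl on a saturated chain carbon bound to an amine nitrogen in a ring. For the measured compounds named here, the single measured step, a number 1 percentage points lower from compound 1 to compound 2 (within the scatter), also concerns the aromatic ring carried on that same saturated chain carbon bound to the amine nitrogen in the ring, and it left the number unchanged beyond the scatter. That swap was a smaller one than the change to compound 3, so it informs the new step only loosely; nothing measured speaks to a nitro group on this ring. Resting on that one step alone, the expected outcome for compound 3 in this assay is a step of a number 3 percentage points lower from compound 2 to compound 3 (within the scatter), meaning no change beyond the scatter, with a wide range allowed. Compound 3 is therefore estimated at 72%, between 52% and 86%.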

Compound 3, a percentage reported as inhibition, at one concentration (the size of the read-out at that concentration, not a potency): 63%
Estimate against measurement, compound 3: 9 percentage points above; low and high end bracket the measured number.
By their numbers in this assay, from the lowest: compound 3; then compounds 2 and 1 (each within the scatter of the next).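

For the compounds shown here, on the saturated chain carbon bound to the amine nitrogen in the ring, the choice of aromatic group can matter: 2-nitrophenyl brings a number 12 percentage points lower from compound 2 to compound 3 (beyond the scatter) and a number 13 percentage points lower from compound 1 to compound 3 (beyond the scatter) in this assay and is the first change here to pass the scatter. Both steps are modest, and compound 3 still gives 63% at the one concentration tested, so this place accepts a quite different substituted phenyl without losing most of the inhibition. Nothing available explains the lower number, and the change replaces both the substituent and its location on the ring at once.

From the compounds shown here alone, it remains open whether the nitro group itself or its location accounts for the step, a question that 4-nitrophenyl and 2-methoxyphenyl at this place could help to separate. Also open, going by these compounds, is how an unsubstituted phenyl or a pyridine ring would compare, and since every number here comes from a single concentration, none of them gives a potency.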